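Thiophene in place of chlorophenyl on the aminothiophene ketone core

A few compounds are considered here, and "the series" means these few. Any claim that something is new, unique, unknown or untested is made for them only; others in the source may bear on it.

Measured compounds:
compound 1 `COc1cc(C(=O)c2sc(-c3ccc([N+](=O)[O-])cc3)cc2N)cc(OC)c1OC`: 99 nM
compound 2 `COc1cc(C(=O)c2sc(-c3ccc(Cl)cc3)cc2N)cc(OC)c1OC`: 70 nM
compound 3 `COc1cc(C(=O)c2sc(-c3ccc(Cl)c(Cl)c3)cc2N)cc(OC)c1OC`: 290 nM

In a functional assay on CCRF-CEM cells (Homo sapiens) for antiproliferative activity (a lower number here means a stronger inhibitor, a higher number a weaker inhibitor), compound 2 gives 70 nM, the lowest of the three numbers; compound 1 sits within the scatter of it, while compound 3 lies beyond. The steps measured so far all change the substituent on the pendant phenyl ring: a 1.4-fold lower number from compound 1 to compound 2 (0.15 log units; within the scatter), a 4.1-fold higher number from compound 2 to compound 3 (0.62 log units; beyond the scatter), and a 2.9-fold higher number from compound 1 to compound 3 (0.47 log units; beyond the scatter). Swapping one para group for another hardly moves the number; adding a second chloro lifts it modestly.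

Compound 4 `COc1cc(C(=O)c2sc(-c3cccs3)cc2N)cc(OC)c1OC` differs from compound 2 at the same place: thiophen-2-yl in place of 4-chlorophenyl on an aromatic carbon. Among the measured compounds shown here, no measured step exchanges the whole aromatic ring, so the closest guide is that the pendant ring tolerates single-group changes with little effect and reacts modestly to a larger alteration. A step of the same modest size, toward a higher number, is expected here, roughly a 2.1-fold higher number from compound 2 to compound 4 (0.33 log units; beyond the scatter). Compound 4 is therefore estimated at 150 nM, with a range from 40 nM to 600 nM in this assay.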

Compound 4, half-maximal inhibitory concentration: 9.4 nM
Estimate against measurement, compound 4: 16-fold (1.20 log units) above; measured number outside the range, below it.
By their numbers in this assay, from the lowest: compound 4; then compounds 2 and 1 (each within the scatter of the next); then compound 3.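

In this assay, thiophen-2-yl in place of 4-chlorophenyl gives a 7.4-fold lower number from compound 2 to compound 4 (0.87 log units; beyond the scatter), whereas none of the substituted phenyl groups shown reaches a number beyond the scatter below that of compound 2. The same exchange gives an 11-fold lower number from compound 1 to compound 4 (1.02 log units; beyond the scatter) and a 31-fold lower number from compound 3 to compound 4 (1.49 log units; beyond the scatter), so the lower number holds against all three phenyl compounds, and this position, on an aromatic carbon next to the ring sulfur, is shown to respond to the identity of the whole ring and not only to the groups carried on a phenyl ring. No supporting measurement bears on why the five-membered ring gives the lower number.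

The compounds shown do not separate the contribution of the ring sulfur from that of the smaller ring, a question that furan-2-yl, thiophen-3-yl or unsubstituted phenyl would address. They also leave open whether the thiophen-2-yl ring accepts further groups, such as a chloro, a methyl or an aminomethyl group, and whether the lower number would survive them.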